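From methyl to trifluoromethoxy in a weakly active pair

The compounds below may be only part of what the source reports. "The series", "measured", "known", "first", "only" and "open" are said of these compounds alone.

- compound 1 `C#CCNC(=O)Nc1cccc(CNCc2ccccc2)c1`: "not active" (no number reported)
- compound 2 `C#CCNC(=O)Nc1cccc(CNCc2ccc(C)cc2)c1`: 329000 nM

Among the measured compounds shown here, in a functional assay on HeLa cells (Homo sapiens) for cytotoxicity, read by MTT assay, with a stated time of 48 h (on this read-out lower numbers stand for stronger inhibition and higher numbers for weaker inhibition), compound 2 gives 329000 nM, the only number available so far, while compound 1 gives "not active" (no number reported) and so offers no number to compare with. The next compound, compound 3 `C#CCNC(=O)Nc1cccc(CNCc2ccc(OC(F)(F)F)cc2)c1`, carries trifluoromethoxy in place of methyl on an aromatic carbon, para to a large group (trifluoromethoxy in place of methyl on an aromatic carbon). For the measured compounds named here, no measured step between two compounds exists to show how much such a change can do, so any forecast is uncertain. A modest move towards stronger inhibition in this assay seems the most likely result, though a result within the scatter would be no surprise. The estimated step of a 1.9-fold lower number from compound 2 to compound 3 (0.29 log units; within the scatter) is therefore small. For compound 3 the expected value is 170000 nM, with an estimated range of 50000 nM to 600000 nM.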

Compound 3, half-maximal inhibitory concentration: 339000 nM
Estimate against measurement, compound 3: 2.0-fold (0.30 log units) below; the range from low to high includes it.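

In this assay, among the compounds shown here, putting trifluoromethoxy in place of methyl on this aromatic carbon, para to a large group, gives a 1.0-fold higher number from compound 2 to compound 3 (0.01 log units; within the scatter) and so provides the first measured step at this position, one that stays within the scatter. The entering group has 5 heavy atoms against 1 for methyl and adds 1 hydrogen-bond acceptor, yet this pair shows no readable difference in the number. No measurement offered here explains why the two compounds read alike.

Still open, from the compounds shown here alone, is whether an amine or a carboxylic acid at this same carbon would give a step beyond the scatter. Also open, going by these compounds, is whether a single chlorine atom or a longer chain there would read any differently from methyl and trifluoromethoxy.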